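The source may report more compounds than this note shows. Statements on the series, on what has been measured and on what is new or still open speak of the compounds shown alone.

Measured compounds in a functional assay on HepG2 cells (Homo sapiens) for antiproliferative activity, read by MTT assay; a higher number here means a weaker inhibitor, a lower number a stronger inhibitor:

- compound 1 `O=C(Nc1ccc(F)cc1)Nc1cccc(CNc2ncnc3ccccc23)c1`: 41500 nM
- compound 2 `O=C(Nc1cccc(CNc2ncnc3ccccc23)c1)Nc1ccccc1Cl`: the value for compound 2 is a limit of this assay, > 50000 nM
- compound 3 `COc1cc2ncnc(NCc3cccc(NC(=O)Nc4ccc(F)cc4)c3)c2cc1OC`: 36600 nM

For the measured compounds named here, the one change measured is 2-chlorophenyl in place of 4-fluorophenyl on an amide-type nitrogen. Its step is an at least 1.2-fold higher number from compound 1 to compound 2 (0.08 log units; that floor lies within the scatter). One of the three values sits at the limit of > 50000 nM in this assay, at which 1 of the 3 values shown sits. Compound 3 and compound 1 differ in their cores; that difference is not broken down here, and their values stand within the scatter of each other.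

Compound 4 `COc1cc2ncnc(NCc3cccc(NC(=O)Nc4ccccc4Cl)c3)c2cc1OC` is not yet measured. It differs from compound 3 by 2-chlorophenyl in place of 4-fluorophenyl on an amide-type nitrogen, the same change as from compound 1 to compound 2, at a place described in the same words. The step is expected to be a 1.5-fold higher number from compound 3 to compound 4 (0.18 log units; within the scatter), resting on the step from compound 1 to compound 2 and on the limit reached there. Compound 4 is accordingly expected at 55000 nM, with a range from 30000 nM to 120000 nM in this assay.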

Compound 4, half-maximal inhibitory concentration: 25500 nM
Estimate against measurement, compound 4: 2.2-fold (0.33 log units) above; the measured number lies below the stated range.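

In this assay, 2-chlorophenyl in place of 4-fluorophenyl on the amide-type nitrogen gives a 1.4-fold lower number from compound 3 to compound 4 (0.16 log units; within the scatter), so on this core the change shows no effect that stands clear of the scatter. On the other core, compound 2 carries a limit of the assay, > 50000 nM. Whether the change carries from one core to the other therefore stays undecided: the same change on two cores in this assay, an at least 1.2-fold higher number (0.08 log units; that floor lies within the scatter) from compound 1 to compound 2 and a 1.4-fold lower number (0.16 log units; within the scatter) from compound 3 to compound 4; the limit leaves it open whether they differ

The compounds shown leave open how an unsubstituted phenyl or a cyclohexyl on the amide-type nitrogen would read on either core. They also leave open whether an amine or a carboxylic acid on that phenyl ring would move a value beyond the scatter in this assay.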